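The compounds below may be only part of what the source reports. "The series", "measured", "known", "first", "only" and "open" are said of these compounds alone.

In a functional assay on HCT-116 cells (Homo sapiens) for antiproliferative activity, read by WST assay, with a stated time of 72 h (on this read-out lower numbers stand for an effect already at smaller amounts and higher numbers for an effect only at larger amounts of compound), compound 1 (`CCCCCCNCC(=O)Nc1ccc(/C(N)=N/O)cc1`) gives 124000 nM. Compound 3 (`CCCCNCC(=O)Nc1ccc(/C(N)=N/O)cc1`) gives 83000 nM, within the scatter of compound 1, and compound 2 (`CCCCCCNCCCC(=O)Nc1ccc(/C(N)=N/O)cc1`) gives the highest number, 312000 nM. Compound 4 (`CCCCNCCCC(=O)Nc1ccc(/C(N)=N/O)cc1`) has the same atoms as compound 1, joined differently: 2-(butylamino)ethyl in place of hexylamino on a saturated chain carbon bound to a carbonyl carbon. It pairs the butylamino group of compound 3 with the longer chain to the carbonyl found in compound 2. Going by the values given here, the only measured step, a 1.5-fold lower number from compound 1 to compound 3 (0.17 log units; within the scatter), suggests that the butyl end alone changes little. The higher number of compound 2, 312000 nM, suggests that the longer chain pushes the number upward. The expected step is a 1.6-fold higher number from compound 1 to compound 4 (0.21 log units; within the scatter), a modest rise. For compound 4 the estimated value is 200000 nM, with an expected range of 100000 nM to 400000 nM.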

Compound 4, half-maximal effective concentration: 267000 nM
The estimate for compound 4 lay 1.3-fold (0.13 log units) below the measured number; measured number inside the range.
By their numbers in this assay, from the lowest: compounds 3 and 1 (each within the scatter of the next); then compounds 4 and 2 (each within the scatter of the next).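

In this assay, 2-(butylamino)ethyl in place of hexylamino gives a 2.2-fold higher number from compound 1 to compound 4 (0.33 log units; beyond the scatter), and in place of butylamino it gives a 3.2-fold higher number from compound 3 to compound 4 (0.51 log units; beyond the scatter), so the rise goes with the longer chain to the carbonyl, not with the butyl end. Trading the hexyl end for the butyl end stays within the scatter on the longer chain too, with a 1.2-fold lower number from compound 2 to compound 4 (0.07 log units; within the scatter), as it did on the shorter one: the same change on two cores in this assay, a 1.5-fold lower number (0.17 log units; within the scatter) from compound 1 to compound 3 and a 1.2-fold lower number (0.07 log units; within the scatter) from compound 2 to compound 4, 1.3-fold (0.11 log units) apart, within the scatter of two such steps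

On these data alone, whether propylamino, or a ring amine such as piperidine, on the saturated chain carbon bound to the carbonyl carbon would bring the number lower stays open.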